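The source may report more compounds than this note shows. Statements on the series, on what has been measured and on what is new or still open speak of the compounds shown alone.

Three compounds share one core and differ only in the group carried on one nitrogen of an aromatic ring. Compound 1 `N#Cc1cnc(NCc2cnccc2C(F)(F)F)cc1NC[C@H]1C[C@H](O)C1` bears a (3-hydroxycyclobutyl)methyl group there, compound 2 `CO[C@H]1CC[C@@H](Nc2cc(NCc3cnccc3C(F)(F)F)ncc2C#N)CC1` a 4-methoxycyclohexyl group, and compound 3 `N#Cc1cnc(NCc2cnccc2C(F)(F)F)cc1NC[C@H]1CC[C@@H](O)CC1` a (4-hydroxycyclohexyl)methyl group. In an assay on isolated protein for inhibition of protein kinase C delta type (Homo sapiens), read by TR-FRET, with a stated time of 2 h (a higher number here means a weaker inhibitor, a lower number a stronger inhibitor), compound 1 gives only a limit of the assay, > 10000 nM. In this assay compound 2 gives 5000 nM, while compound 3 gives 500 nM. Of the two true numbers, compound 2 has the highest, and the nearest is compound 3, separated by a 10-fold lower number from compound 2 to compound 3 (1.00 log units; beyond the scatter). The step of an at least 20-fold lower number from compound 1 to compound 3 (1.30 log units; beyond the scatter) is large, and the step of an at least 2.0-fold lower number from compound 1 to compound 2 (0.30 log units; that floor lies within the scatter) rests on a limit.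

Compound 4 `N#Cc1cnc(NCc2cnccc2C(F)(F)F)cc1N[C@H]1CC[C@@H](c2nc[nH]n2)CC1` differs from compound 2 by 1H-1,2,4-triazol-3-yl in place of methoxy on a saturated ring carbon. The step that bears most on this change is a 10-fold lower number from compound 2 to compound 3 (1.00 log units; beyond the scatter), where replacing the methoxy-bearing ring by one carrying a hydroxyl with its hydrogen-bond donor lowered the number clearly. The incoming triazolyl also brings a hydrogen-bond donor, so a lowering of similar size is expected in this assay, about a 13-fold lower number from compound 2 to compound 4 (1.10 log units; beyond the scatter). Compound 4 is therefore estimated at 400 nM, within 60 nM to 2500 nM.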

Compound 4, half-maximal inhibitory concentration: 1200 nM
For compound 4 the middle estimate is 3.0-fold (0.48 log units) below the measured one; the measured number falls inside the stated range.
By their numbers in this assay, from the lowest: compound 3; then compound 4; then compound 2. At a limit, above all of these: compound 1.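

In this assay, 1H-1,2,4-triazol-3-yl in place of methoxy on a saturated ring carbon gives a 4.2-fold lower number from compound 2 to compound 4 (0.62 log units; beyond the scatter), the first step shown in which only the group on that ring carbon changes. The earlier step to compound 3 replaced the whole group on the nitrogen, so it could not show that this ring carbon alone can shift the number, or that a five-membered aromatic ring can stand there with a lower number than methoxy gives. Nothing measured here accounts for the size of this step.

From the compounds shown here alone, how a hydroxyl, an amine or a carboxylic acid on this same ring carbon would read in this assay remains open. Also open, going by these compounds, is whether the hydrogen on the triazole nitrogen matters, which a triazole carrying a methyl group on that nitrogen could test.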